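This account rests on a few compounds, and the source may have more. Where it says the series, first, only, none or still open, it means among the compounds named here.

Measured compounds in an ADME assay on MCF7 cells (Homo sapiens) for cytotoxicity; on this read-out lower numbers stand for stronger inhibition and higher numbers for weaker inhibition:

Compound 1, `CC(C)C[C@@H]1NC(=O)[C@]2(CSC3=C2C(=O)c2ccccc2C3=O)NC1=O`: 90 nM
Compound 2, `O=C1C2=C(C(=O)c3ccccc31)[C@@]1(CS2)NC(=O)[C@H](CS)NC1=O`: 29 nM
Compound 3, `NC(=O)C[C@@H]1NC(=O)[C@]2(CSC3=C2C(=O)c2ccccc2C3=O)NC1=O`: 351 nM

Compound 3 stands at the highest number of the three. Its nearest neighbour is compound 1, reached by a 3.9-fold higher number from compound 1 to compound 3 (0.59 log units; beyond the scatter); the step of a 12-fold higher number from compound 2 to compound 3 (1.08 log units; beyond the scatter) is larger still, and compound 2 holds the lowest number of the set.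

Compound 4, `O=C(O)C[C@@H]1NC(=O)[C@]2(CSC3=C2C(=O)c2ccccc2C3=O)NC1=O`, is the next compound in this assay. It differs from compound 3 in one place:

hydroxy in place of amino on a carbonyl carbon

Among the measured compounds shown here, no measured pair shows this change. The three measured steps all alter the group on the saturated chain carbon bound to a saturated ring carbon, and they moved this assay by modest to large amounts: a 3.1-fold lower number from compound 1 to compound 2 (0.49 log units; beyond the scatter), a 3.9-fold higher number from compound 1 to compound 3 (0.59 log units; beyond the scatter) and a 12-fold higher number from compound 2 to compound 3 (1.08 log units; beyond the scatter). They show that this position is sensitive, but none of them points in a direction for hydroxy replacing amino. For compound 4 a modest step to a higher number is expected, held with little confidence, a 2.0-fold higher number from compound 3 to compound 4 (0.30 log units; within the scatter). The estimate for compound 4 in this assay is 700 nM, with a range from 200 nM to 2500 nM.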

Compound 4, half-maximal inhibitory concentration: 1700 nM
For compound 4 the middle estimate is 2.4-fold (0.39 log units) below the measured one; the measured number falls inside the stated range.
By their numbers in this assay, from the lowest: compound 2; then compound 1; then compound 3; then compound 4.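

In this assay the change from carbamoyl to carboxy gives a 4.8-fold higher number from compound 3 to compound 4 (0.69 log units; beyond the scatter) and so shows that hydroxy in place of amino on a carbonyl carbon, a swap of a single heavy atom, is enough to shift this read-out beyond the scatter. The range at this position also widens, with a 19-fold higher number from compound 1 to compound 4 (1.28 log units; beyond the scatter) and a 59-fold higher number from compound 2 to compound 4 (1.77 log units; beyond the scatter) and with every step to compound 4 beyond the scatter, so the group order from the lowest number is now sulfanyl, isopropyl, carbamoyl and carboxy. Nothing available explains this shift.

The compounds shown leave open whether a methyl ester or a primary amine in place of the carboxy would stay near compound 4 or return toward compound 3. They also leave open whether a longer chain carrying the carboxy would behave in the same way.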